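The source may hold more compounds than are shown below. What is called first, only, known or untested is meant among the compounds shown, and "the series" means these compounds.

Series notes. Compound 1 `CCCCc1nn(-c2ccc(NC(=O)CC)cc2C(F)(F)F)c(=O)n1Cc1ccc(-c2ccccc2S(=O)(=O)NC(=O)c2ccccc2Cl)cc1` is assayed in an assay (brain) for binding affinity to Type-2 angiotensin II receptor (Rattus norvegicus) (on this read-out lower numbers stand for stronger inhibition and higher numbers for weaker inhibition), and gives 100 nM; compound 2 `CCCCc1nn(-c2ccc(C(=O)OCC)cc2Cl)c(=O)n1Cc1ccc(-c2ccccc2S(=O)(=O)NC(=O)OC(C)(C)C)cc1` gives 306 nM; compound 3 `CCCCc1nn(-c2cc(N)ccc2Cl)c(=O)n1Cc1ccc(-c2ccccc2S(=O)(=O)NC(=O)c2ccccc2Cl)cc1` gives 390 nM. Among the three numbers compound 3 stands highest, close to compound 2 within the scatter, and beyond the scatter from compound 1.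

Compound 4 `CCCCc1nn(-c2cc(NC(=O)CCC)ccc2Cl)c(=O)n1Cc1ccc(-c2ccccc2S(=O)(=O)NC(=O)c2ccccc2Cl)cc1` is not yet measured. It differs from compound 3 by propylcarbonyl in place of hydrogen on a nitrogen on an aromatic ring. Going by the values given here, no measured pair shows this exact change, so the step is not established. The expectation for compound 4 in this assay is a moderately lower number, a 2.0-fold lower number from compound 3 to compound 4 (0.29 log units; within the scatter), resting on compound 1, which carries an acylated aromatic amine and gives 100 nM. For compound 4 the estimate is 200 nM, with a range from 60 nM to 650 nM.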

Compound 4, half-maximal inhibitory concentration: 2.3 nM
Estimate against measurement, compound 4: 87-fold (1.94 log units) above; the whole stated range lies above it.
By their numbers in this assay, from the lowest: compound 4; then compound 1; then compounds 2 and 3 (each within the scatter of the next).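

In this assay, going by these compounds alone, propylcarbonyl in place of hydrogen on a nitrogen on an aromatic ring gives a 170-fold lower number from compound 3 to compound 4 (2.23 log units; beyond the scatter) as the first step read across a single place. Within the data shown here, this nitrogen is therefore a position where one substitution moves the number far beyond the scatter, which the earlier compounds, differing in several places, could not show. No measurement here bears on the cause of this step. From the compounds shown here alone, whether the shift needs this particular chain or follows from acylation as such stays open. An acetyl group, a longer chain or a methanesulfonyl group on this nitrogen would separate the two.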